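From difluorophenyl to methylphenyl on a shared core

The compounds below may be only part of what the source reports. "The series", "measured", "known", "first", "only" and "open" are said of these compounds alone.

- Compound 1 `CSc1ccc(C2=C(c3ccc(F)c(F)c3)C(=O)N3CCCC3C2)cc1`: 100 nM
- Compound 2 `COc1ccc(C2=C(c3ccc(SC)cc3)CC3CCCN3C2=O)cc1OC`: 9000 nM

In a functional assay on SK-OV-3 cells (Homo sapiens) for cytotoxicity (on this read-out higher numbers stand for weaker inhibition of growth and lower numbers for stronger inhibition of growth), compound 1 holds the lower of the two numbers, and the gap up to compound 2 lies beyond the scatter. Compound 3 `CSc1ccc(C2=C(c3ccc(C)cc3)C(=O)N3CCCC3C2)cc1` keeps the core of compound 1 and carries 4-methylphenyl in place of 3,4-difluorophenyl on a double-bonded ring carbon. Within the data shown here, no measured pair shows this change, so the expectation rests on the structures alone. The expected step of a 3.0-fold higher number from compound 1 to compound 3 (0.48 log units; beyond the scatter) is a modest one toward a higher number in this assay, possibly not far beyond the scatter. For compound 3 the estimated value is 300 nM, with an expected range from 80 nM to 1500 nM.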

Compound 3, concentration for 50% growth inhibition: 9000 nM
For compound 3 the middle estimate is 30-fold (1.48 log units) below the measured one, and the stated range ends below it.
By their numbers in this assay, from the lowest: compound 1; then compounds 2 and 3 (each within the scatter of the next).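

In this assay, placing 4-methylphenyl where compound 1 carries 3,4-difluorophenyl on a double-bonded ring carbon gives a 90-fold higher number from compound 1 to compound 3 (1.95 log units; beyond the scatter) and shows that the read-out is highly sensitive to the group at this position. The two groups match in their aromatic ring of carbon only and in their counts of hydrogen-bond donors and acceptors, so those features do not separate them. Nothing available explains the size of this step. The compounds shown leave open whether the higher number follows the loss of fluorine or the arrival of the methyl. Plain phenyl or 4-fluorophenyl at this position would help separate the two.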